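The source may hold more compounds than are shown below. What is called first, only, known or untested is meant among the compounds shown, and "the series" means these compounds.

In a functional assay on RS4-11 cells (Homo sapiens) for inhibition, read by CCK-8 assay, with a stated time of 72 h (on this read-out higher numbers stand for weaker inhibition and lower numbers for stronger inhibition), compound 1 (`COc1ccc(C2=C(CN3CCN(c4ccc(C(=O)NS(=O)(=O)c5ccc(NCC6CCOCC6)c([N+](=O)[O-])c5)c(Oc5cnc6[nH]ccc6c5)c4)CC3)CCC(C)(C)C2)cc1`) gives 12 nM, compound 2 (`CC1(C)CCC(CN2CCN(c3ccc(C(=O)NS(=O)(=O)c4ccc(NCC5CCOCC5)c([N+](=O)[O-])c4)c(Oc4cnc5[nH]ccc5c4)c3)CC2)=C(c2cccc(C(F)(F)F)c2)C1`) gives 63 nM, and compound 3 (`CN(C)CCCNc1ccc(S(=O)(=O)NC(=O)c2ccc(N3CCN(CC4=C(c5ccc(C(F)(F)F)cc5)CC(C)(C)CC4)CC3)cc2Oc2cnc3[nH]ccc3c2)cc1[N+](=O)[O-]`) stands lowest of the three at 3.9 nM. Compound 4 (`CC1(C)CCC(CN2CCN(c3ccc(C(=O)NS(=O)(=O)c4ccc(NCC5CCOC5)c([N+](=O)[O-])c4)c(Oc4cnc5[nH]ccc5c4)c3)CC2)=C(c2ccc(C(F)(F)F)cc2)C1`) departs from compound 3 in one place, on a saturated chain carbon bound to a nitrogen on an aromatic ring: oxolan-3-yl in place of 2-(dimethylamino)ethyl on a saturated chain carbon bound to a nitrogen on an aromatic ring. Within the data shown here, no measured step covers this change. The only one available, a 5.3-fold higher number from compound 1 to compound 2 (0.72 log units; beyond the scatter), lies elsewhere, on a double-bonded ring carbon, and serves merely as a guide to size. Compound 3 carries the 3-(dimethylamino)propyl chain, whereas compound 1, which lacks it, gives 12 nM. A modest rise is therefore expected, a 3.8-fold higher number from compound 3 to compound 4 (0.59 log units; beyond the scatter). Compound 4 is estimated at 15 nM, within a range of 5 nM to 50 nM.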

Compound 4, half-maximal inhibitory concentration: 24.2 nM
Compound 4: middle estimate off by 1.6-fold (0.21 log units), on the low side, and the stated range covers the measured number.
By their numbers in this assay, from the lowest: compound 3; then compounds 1 and 4 (each within the scatter of the next); then compound 2.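

In this assay, (oxolan-3-yl)methyl taking the place of 3-(dimethylamino)propyl gives a 6.2-fold higher number from compound 3 to compound 4 (0.79 log units; beyond the scatter), the first step read at this position. The number therefore responds to the group here, even though 2-(dimethylamino)ethyl and oxolan-3-yl have the same count of 5 heavy atoms and each has 1 hydrogen-bond acceptor. Nothing on hand accounts for the size of this step.

The compounds shown do not separate the loss of the dimethylamino nitrogen from the arrival of the ring. A morpholine ring or a primary amine on the same chain would begin to tell these apart.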